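The source may report more compounds than this note shows. Statements on the series, on what has been measured and on what is new or still open speak of the compounds shown alone.

Compound 1 `COC(=O)C1=C(C)NC(=O)NC1c1cccs1` gives 6% in an assay on membranes from CHO cells for displacement of a labelled ligand from adenosine receptor A1 (Homo sapiens), read by scintillation counting, with a stated time of 60 min, tested at 1 uM; on this read-out higher numbers stand for more inhibition at the one concentration tested (going by the name of the read-out) and lower numbers for less inhibition. Compound 2 `CCSC(=O)C1=C(C)NC(=O)NC1c1ccoc1` gives 3% in this assay; this is the lower of the two numbers, but its gap to compound 1 lies within the usual scatter, so the two cannot be ordered. Compound 3 `CCSC(=O)C1=C(C)NC(=O)NC1c1cccs1` has not yet been measured in this assay. It differs from compound 2 in one place: thiophen-2-yl in place of furan-3-yl on a saturated ring carbon. Going by the values given here, no measured pair of compounds shows this change alone, so its effect in this assay is not known from the data. Both measured numbers are low, and the expected step is a number 2 percentage points higher from compound 2 to compound 3 (within the scatter), not beyond the scatter. Compound 3 is expected to give about 5%, within a range from 0% to 15%.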

Compound 3, a percentage reported as inhibition, at one concentration (the size of the read-out at that concentration, not a potency): 6%
For compound 3 the middle estimate is 1 percentage points below the measured one; low and high end bracket the measured number.
By their numbers in this assay, from the lowest: compounds 2, 1 and 3 (each within the scatter of the next).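

In this assay, thiophen-2-yl in place of furan-3-yl on a saturated ring carbon gives a number 3 percentage points higher from compound 2 to compound 3 (within the scatter), and ethylsulfanyl in place of methoxy on a carbonyl carbon gives no change at the digits printed from compound 1 to compound 3 (within the scatter). Neither single change therefore moves the number beyond the scatter, so these steps separate neither the two aromatic rings nor the two groups on the carbonyl carbon. Nothing available here speaks to a cause for this. Open, on these data alone, is whether an amine or a carboxylic acid in place of the thiophen-2-yl, or a longer chain in place of the ethylsulfanyl, would give a number beyond the scatter.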